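Aryl Swap on the Hydrazone Series and Transaminase Inhibition

The source may report more compounds than this note shows. Statements on the series, on what has been measured and on what is new or still open speak of the compounds shown alone.

Measured compounds:
Compound 1 `O=C(O)CCc1c(C(=O)O)[nH]c2ccc([N+](=O)[O-])cc12` — 666000 nM
Compound 2 `CCOC(=O)/C(CCCC(=O)O)=N\Nc1cccc(Cl)c1` — 20000 nM
Compound 3 `Cc1ccc2[nH]c(C(=O)O)c(CCC(=O)O)c2c1` — > 1000000 nM

In an assay on isolated protein for inhibition of kynurenine--oxoglutarate transaminase 1 (Homo sapiens), read by HPLC, with a stated time of 20 min (on this read-out higher numbers stand for weaker inhibition and lower numbers for stronger inhibition), compound 2 gives the lowest of the two numbers shown; compound 1 sits well above it. Compound 3 returns only a limit, (the limit of > 1000000 nM in this assay, at which 1 of the 3 values shown sits), and no number. Among the measured compounds shown here, the one measured step, an at least 1.5-fold higher number from compound 1 to compound 3 (0.17 log units; that floor lies within the scatter), concerns a different core but likewise replaces an electron-poor substituent with a methyl, and it points weaker, though its floor lies within the scatter.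

Compound 4 `CCOC(=O)/C(CCCC(=O)O)=N\Nc1ccc(C)cc1` differs from compound 2 by 4-methylphenyl in place of 3-chlorophenyl on an amine nitrogen. Drawing on that single step, a modest move toward weaker inhibition is expected, a 2.5-fold higher number from compound 2 to compound 4 (0.40 log units; beyond the scatter), so compound 4 is estimated at 50000 nM, between 15000 nM and 200000 nM.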

Compound 4, half-maximal inhibitory concentration: 33000 nM
Compound 4: middle estimate off by 1.5-fold (0.18 log units), on the high side; measured number inside the range.
By their numbers in this assay, from the lowest: compounds 2 and 4 (each within the scatter of the next); then compound 1. At a limit, above all of these: compound 3.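

In this assay, 4-methylphenyl in place of 3-chlorophenyl on an amine nitrogen gives a 1.7-fold higher number from compound 2 to compound 4 (0.22 log units; within the scatter). This is the first step shown at this position, and the two aryl groups cannot be told apart here, so the hydrazone pair shows that this exchange leaves the read-out unresolved. Nothing shown bears on why the two groups read alike. The exchange alters both the substituent and where it sits on the ring, and these two changes remain unseparated. As far as these compounds go, whether a 4-chlorophenyl, a 4-methoxyphenyl or a pyridyl ring on that nitrogen would read differently stays open.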